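This account rests on a few compounds, and the source may have more. Where it says the series, first, only, none or still open, it means among the compounds named here.

Measured so far in an assay on isolated protein for displacement of a labelled ligand from 5-hydroxytryptamine receptor 6 (Homo sapiens); on this read-out lower numbers stand for stronger inhibition and higher numbers for weaker inhibition:
compound 1 `CNS(=O)(=O)NC[C@@H]1CCCc2cc(S(=O)(=O)c3cccc(F)c3)ccc21`: 1 nM
compound 2 `COCCNC[C@@H]1CCCc2cc(S(=O)(=O)c3cccc(F)c3)ccc21`: 0.251 nM

Among the compounds with values here, compound 2 holds the lowest of the two numbers; compound 1 is the only neighbour, a step away by a 4.0-fold lower number from compound 1 to compound 2 (0.60 log units; beyond the scatter). Compound 3 `CNCC(=O)NC[C@@H]1CCCc2cc(S(=O)(=O)c3cccc(F)c3)ccc21` is not yet measured; it differs from compound 2 by ((methylamino)methyl)carbonyl in place of 2-methoxyethyl on an amine nitrogen. Within the data shown here, the one measured step that bears on it is the one from compound 1 to compound 2, where 2-methoxyethyl on this nitrogen replaced methylsulfamoyl and gave a 4.0-fold lower number from compound 1 to compound 2 (0.60 log units; beyond the scatter). Among the measured compounds shown here, compound 3 removes the 2-methoxyethyl again and puts a group carrying a carbonyl in its place, so the change is expected to run the other way, toward a higher number, of roughly the size seen between compound 1 and compound 2; no measured pair shows what the methylamino end of the new group adds. Compound 3 is expected at 1 nM, between 0.3 nM and 4 nM. The expected step is thus a 4.0-fold higher number from compound 2 to compound 3 (0.60 log units; beyond the scatter).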

Compound 3, inhibition constant: 0.159 nM
Beside the measured number, compound 3's estimate is 6.3-fold (0.80 log units) above it; measured number below the stated range.
By their numbers in this assay, from the lowest: compounds 3 and 2 (each within the scatter of the next); then compound 1.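

In this assay, the amine nitrogen carries ((methylamino)methyl)carbonyl as well as it carries 2-methoxyethyl, with a 1.6-fold lower number from compound 2 to compound 3 (0.20 log units; within the scatter), so a carbonyl in the group on this nitrogen does not by itself bring a higher number. The step against methylsulfamoyl, a 6.3-fold lower number from compound 1 to compound 3 (0.80 log units; beyond the scatter), shows that compound 1 stands apart from both compound 2 and compound 3, whose two groups share no more than their open-chain form and an oxygen. Nothing available explains this tolerance or the standing of methylsulfamoyl.

The compounds shown leave open whether the methylamino end contributes at all, which a plain acetyl group on the same nitrogen would test. From the compounds shown here alone, how far this position extends is also open, for instance to a longer chain ending in a dimethylamino group or to a carboxylic acid.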